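Swapping the aryl group on the triazole nitrogen

The source may hold more compounds than are shown below. What is called first, only, known or untested is meant among the compounds shown, and "the series" means these compounds.

Of the compounds shown here, three have been measured in a functional assay on MKN-45 cells (Homo sapiens) for inhibition, read by CCK-8 assay, with a stated time of 24 h; a lower number here means a stronger inhibitor, a higher number a weaker inhibitor. Compound 1 (`O=C1Nc2ccccc2/C1=C/c1ccc(-c2cn(-c3ccccc3F)nn2)cc1`) gives 12500 nM, compound 2 (`Cc1cccc(-n2cc(-c3ccc(/C=C4\C(=O)Nc5ccc(F)cc54)cc3)nn2)c1`) gives 6810 nM, and compound 3 (`Cc1ccc(-n2cc(-c3ccc(/C=C4\C(=O)Nc5ccc(F)cc54)cc3)nn2)cc1`) gives 34600 nM, the highest of the three numbers and so the weakest inhibitor of the set. Compound 4 (`O=C1Nc2ccc(F)cc2/C1=C/c1ccc(-c2cn(-c3ccccc3F)nn2)cc1`) keeps the core of compound 3 but carries 2-fluorophenyl in place of 4-methylphenyl on an aromatic nitrogen.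

For the measured compounds named here, only one measured step changes this same group, namely a 5.1-fold higher number from compound 2 to compound 3 (0.71 log units; beyond the scatter). It shows that the group on this nitrogen can shift the number by a modest amount, although it involves no fluorine. The closest guide to the incoming group is compound 1 at 12500 nM, which bears the same 2-fluorophenyl but has a core without the fluorine shared by compounds 2, 3 and 4. Together these point to a modest move towards a lower number in this assay, with compound 4 landing near compound 1 rather than near compound 3. The estimate amounts to a 3.1-fold lower number from compound 3 to compound 4 (0.50 log units; beyond the scatter). For compound 4 the expected value is 11000 nM, with an estimated range from 3500 nM to 30000 nM.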

Compound 4, half-maximal inhibitory concentration: 8510 nM
The estimate for compound 4 lay 1.3-fold (0.11 log units) above the measured number; low and high end bracket the measured number.
By their numbers in this assay, from the lowest: compounds 2, 4 and 1 (each within the scatter of the next); then compound 3.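

In this assay the 2-fluorophenyl group on the aromatic nitrogen brings the number back down, with a 4.1-fold lower number from compound 3 to compound 4 (0.61 log units; beyond the scatter) as the step, which ties the high number of compound 3 to its 4-methylphenyl group rather than to the shared core. Set against 3-methylphenyl, the same group makes no readable difference, with a 1.2-fold higher number from compound 2 to compound 4 (0.10 log units; within the scatter) as the step, so 4-methylphenyl is the only one of the three groups on this core that stands apart. The fluoro on the core could not be judged alone before, and with 2-fluorophenyl held constant it also makes no readable difference, with a 1.5-fold lower number from compound 1 to compound 4 (0.17 log units; within the scatter) as the step.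

No evidence accompanies these compounds to say why the numbers differ. From the compounds shown here alone, the groups on this nitrogen are all phenyl rings carrying a single methyl or fluoro, so it remains open how the number would respond to a methoxy group, an amine or a carboxylic acid on that ring, or to a longer alkyl chain in place of the ring.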